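Pyridinyl for oxazolyl on a sulfonamide across two cores

The source may report more compounds than this note shows. Statements on the series, on what has been measured and on what is new or still open speak of the compounds shown alone.

Two cores are compared. Compound 1 `Cc1cc(NS(=O)(=O)c2ccc(NCc3coc4ccccc4c3=O)cc2)no1` and compound 3 `Cc1cc(NS(=O)(=O)c2ccc(N3C(=O)/C(=C/c4coc5ccccc5c4=O)N=C3c3ccc(Cl)cc3)cc2)no1` both carry a sulfonamide; the difference between their two cores is not broken down here. In a functional assay on MCF7 cells (Homo sapiens) for cytotoxicity, read by sulforhodamine B assay, with a stated time of 72 h (a higher number here means a weaker inhibitor, a lower number a stronger inhibitor), compound 1 gives 34500 nM. Compound 2 `O=c1c(CNc2ccc(S(=O)(=O)Nc3ccccn3)cc2)coc2ccccc12` shows (pyridin-2-yl in place of 5-methyl-1,2-oxazol-3-yl on a sulfonamide nitrogen). In this assay compound 2 reaches only the limit of the assay, > 100000 nM. The result is an at least 2.8-fold higher number from compound 1 to compound 2 (0.46 log units; beyond the scatter). Compound 3 also sits at the limit in this assay, > 100000 nM. Compound 4 `O=C1/C(=C/c2coc3ccccc3c2=O)N=C(c2ccc(Cl)cc2)N1c1ccc(S(=O)(=O)Nc2ccccn2)cc1` carries the same kind of change on the core of compound 3, (pyridin-2-yl in place of 5-methyl-1,2-oxazol-3-yl on a sulfonamide nitrogen). The step from compound 3 to compound 4 is expected to be a step that the limit leaves unreadable from compound 3 to compound 4, and most likely again only a limit. This rests on compound 3 already standing at the limit of > 100000 nM in this assay, at which 2 of the 3 values shown sit. It also rests on the earlier at least 2.8-fold higher number from compound 1 to compound 2 (0.46 log units; beyond the scatter). Compound 4 is therefore expected at 200000 nM, between 100000 nM and 1000000 nM.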

Compound 4, half-maximal inhibitory concentration: > 100000 nM
Compound 4 was reported as a limit; the forecaster's own chance of this, stated with the estimate: 90%; the middle value does not contradict the limit.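

Compound 3 and compound 4 are both reported only as a limit, so no step between them can be read: the limit of > 100000 nM in this assay, at which 3 of the 4 values shown sit.

The compounds shown leave open how far pyridin-2-yl in place of 5-methyl-1,2-oxazol-3-yl shifts the number on the core of compound 3.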